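Removing the Amino Acid from a Quinone: Expected Cytotoxicity

This account rests on a few compounds, and the source may have more. Where it says the series, first, only, none or still open, it means among the compounds named here.

Compound 1 `CC(C)(C)C1=CC(=O)C=C(NCCC(=O)O)C1=O`: 28400 nM
Compound 2 `CC1=CCC[C@H]2[C@](C)(CC3=CC(=O)C(N4CCC[C@H]4C(=O)O)=CC3=O)[C@@H](C)CC[C@]12C`: 39600 nM

Both values come from a functional assay on Fem-X cells (Homo sapiens) for cytotoxicity, read by MTT assay, with a stated time of 72 h; on this read-out lower numbers stand for stronger inhibition and higher numbers for weaker inhibition. Of the two numbers, compound 2 gives the higher one, yet its gap to compound 1 lies within the scatter, so the two cannot truly be ordered. Compound 3 `CC1=CCC[C@H]2[C@](C)(CC3=CC(=O)C=CC3=O)[C@@H](C)CC[C@]12C` has not yet been measured. It differs from compound 2 by hydrogen in place of 2-carboxypyrrolidin-1-yl on a double-bonded ring carbon. For the measured compounds named here, no step between measured compounds is available to calibrate this change, so the expectation rests on the two values alone. Compound 3 is expected to give a modestly lower number, a step of a 2.6-fold lower number from compound 2 to compound 3 (0.42 log units; beyond the scatter) that may not exceed the scatter. The estimate for compound 3 is 15000 nM, between 4000 nM and 60000 nM.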

Compound 3, half-maximal inhibitory concentration: 40300 nM
Compound 3: the middle estimate sits 2.7-fold (0.43 log units) below what was measured; measured number inside the range.
By their numbers in this assay, from the lowest: compounds 1, 2 and 3 (each within the scatter of the next).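

In this assay, for the compounds shown here, hydrogen in place of 2-carboxypyrrolidin-1-yl on a double-bonded ring carbon gives a 1.0-fold higher number from compound 2 to compound 3 (0.01 log units; within the scatter), the first step that can be read at this position. Compound 3 therefore shows that cytotoxicity at this level does not depend on the presence of this group, whose removal takes away eight heavy atoms and a five-membered ring. No measurement offered here explains this result. The compounds shown leave open whether a simple amine or a carboxylic acid on a longer chain at this ring carbon would give a number beyond the scatter from compound 3.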